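From an inactive methyl analogue to a trifluoromethyl variant

The source may report more compounds than this note shows. Statements on the series, on what has been measured and on what is new or still open speak of the compounds shown alone.

Compound 1 `C=CCn1c(=O)/c(=C\c2cccc(Br)c2)[nH]c(=O)/c1=C\c1ccccc1OC`: 1100 nM
Compound 2 `C=CCn1c(=O)/c(=C\c2ccccc2F)[nH]c(=O)/c1=C\c1ccccc1OC`: 5500 nM
Compound 3 `C=CCn1c(=O)/c(=C\c2ccc(C)cc2)[nH]c(=O)/c1=C\c1ccccc1OC`: "not active" (no number reported)

In a functional assay on U-937 cells (Homo sapiens) for cytotoxicity, read by CCK-8 assay, with a stated time of 72 h (a higher number here means a weaker inhibitor, a lower number a stronger inhibitor), compound 1 gives 1100 nM and compound 2 gives 5500 nM, which amounts to a 5.0-fold higher number from compound 1 to compound 2 (0.70 log units; beyond the scatter). Compound 3 stands apart: it is reported as "not active" (no number reported) with no single number, so it cannot be placed against the other two. Compound 4 `C=CCn1c(=O)/c(=C\c2ccccc2C(F)(F)F)[nH]c(=O)/c1=C\c1ccccc1OC` differs from compound 3 by 2-(trifluoromethyl)phenyl in place of 4-methylphenyl on a double-bonded chain carbon bound to an aromatic carbon. For the measured compounds named here, the one measured step concerns a different pair of groups and does not bear directly on this change, and with no number for compound 3 no size or direction of step in this assay can be stated. Resting on compounds 1 and 2 alone, compound 4 is expected to give about 3000 nM, estimated between 800 nM and 15000 nM.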

Compound 4, half-maximal inhibitory concentration: 1500 nM
Beside the measured number, compound 4's estimate is 2.0-fold (0.30 log units) above it, and the stated range covers the measured number.
By their numbers in this assay, from the lowest: compounds 1 and 4 (each within the scatter of the next); then compound 2.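

In this assay compound 4 shows that a measurable number can be had at this double-bonded chain carbon with 2-(trifluoromethyl)phenyl, whereas compound 3, with 4-methylphenyl, is reported only as not active, so that step cannot be read. Trifluoromethyl in place of fluoro gives a 3.7-fold lower number from compound 2 to compound 4 (0.56 log units; beyond the scatter) while 2-(trifluoromethyl)phenyl in place of 3-bromophenyl gives a 1.4-fold higher number from compound 1 to compound 4 (0.13 log units; within the scatter) and leaves those two groups indistinguishable in this assay. Nothing available here explains these differences.

On these data alone, whether an amine or a carboxylic acid on this phenyl ring would keep such a number remains open.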